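Ring stereocentre inversion within the series

The source may hold more compounds than are shown below. What is called first, only, known or untested is meant among the compounds shown, and "the series" means these compounds.

Of the compounds shown here, three have been measured in an assay on HEK293 cells for agonist activity at probable G-protein coupled receptor 34 (Mus musculus), with a stated time of 1 h; a lower number here means a smaller maximal response, a higher number a larger maximal response. Compound 1 `CCCCCCCC/C=C\CCCCCCCC(=O)OC[C@H](COC)OP(=O)(O)OC[C@H](N)C(=O)O` gives 7.5% in this assay. Compound 2 `COC[C@H](COC(=O)CCc1ccccc1OCc1cccc(Oc2ccccc2)c1)OP(=O)(O)OC[C@H](N)C(=O)O` gives 13.5% in this assay. Compound 3 `CCCCCCCCCCCOc1ccccc1CCC(=O)O[C@H]1COCC[C@H]1OP(=O)(O)OC[C@H](N)C(=O)O` gives 3.7% in this assay. The number for compound 3 is the lowest of the three, yet its gap to compound 1 and its gap to compound 2 both lie within the usual scatter of repeated measurements, so the three numbers cannot be ordered with confidence; all three sit at a small maximal response.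

Compound 4 `CCCCCCCCCCCOc1ccccc1CCC(=O)O[C@H]1COCC[C@@H]1OP(=O)(O)OC[C@H](N)C(=O)O` has not been measured. It differs from compound 3 as follows: the two compounds have the same atoms and bonds; at least one stereo element is drawn with a configuration in one of them and without one in the other: 1 of 4 stereo elements differ; a stereocentre at a saturated ring carbon is drawn R in compound 3 and S in compound 4. No step between measured compounds of the series is available for comparison, so no pattern can be drawn from the numbers shown.

Among the compounds with values here, with all three measured numbers small and no step on record, compound 4 is expected to give a maximal response in this assay of 6%, with a range from 0% to 16%. The step expected here, a number 2.3 percentage points higher from compound 3 to compound 4 (within the scatter), is estimated to stay within the scatter, in no clear direction.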

Compound 4, largest response reached (Emax), in percent of the reference or control that the assay uses: "not active" (no number reported)
The entry for compound 4 holds no number; no gap can be computed for the estimate.
By their numbers in this assay, from the lowest: compounds 3, 1 and 2 (each within the scatter of the next).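

Within the data shown here, compound 4 is entered as not active with no number, and no step from compound 3 to compound 4 can be read. From the compounds shown here alone, whether the R or S drawing at the saturated ring carbon alters the response in this assay stays open. Nothing on record accounts for the entry.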